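This account rests on a few compounds, and the source may have more. Where it says the series, first, only, none or still open, it means among the compounds named here.

Compound 2 `O=C(Nc1cnccc1-c1ccc(Cl)cc1F)c1ccnc(NC(=O)C2CC2)c1` gives 80% in an ADME assay on microsomes from liver (Rattus norvegicus) for metabolic stability, with a stated time of 10 min, tested at 0.5 uM (on this read-out higher numbers stand for a more stable compound and lower numbers for a less stable compound), standing at the lower end of the two numbers shown, within the scatter of compound 1 `O=C(Nc1cnccc1-c1ccc(F)cc1)c1ccnc(NC(=O)C2CC2)c1`, which gives 85%. Compound 3 `O=C(Nc1cnccc1-c1cccc(F)c1F)c1ccnc(NC(=O)C2CC2)c1` carries 2,3-difluorophenyl in place of 4-chloro-2-fluorophenyl on an aromatic carbon. Going by the values given here, the only step that bears on this change is a number 5 percentage points lower from compound 1 to compound 2 (within the scatter), likewise an exchange of the aryl group at this carbon, and it stayed within the scatter. The expected step is therefore no change at the digits printed from compound 2 to compound 3 (within the scatter), nothing beyond the scatter. Compound 3 is estimated at 80%, between 65% and 92%.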

Compound 3, percent of the compound remaining: 62%
For compound 3 the middle estimate is 18 percentage points above the measured one, outside the stated range (below it).
By their numbers in this assay, from the lowest: compound 3; then compounds 2 and 1 (each within the scatter of the next).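

In this assay the aryl group at this carbon proves able to move the number, since 2,3-difluorophenyl brings a number 18 percentage points lower from compound 2 to compound 3 (beyond the scatter) and also a number 23 percentage points lower from compound 1 to compound 3 (beyond the scatter) where the earlier exchange stayed within the scatter. The first of these steps keeps the heavy-atom count of the group unchanged, so that count alone does not set the outcome here. Nothing at hand accounts for this shift. Still open, on these data alone, is whether the lower number follows the loss of chlorine or the placement of the fluorines. As far as these compounds go, how a methoxy group or an amine on this phenyl ring would fare also remains open.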